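Bis-amide series at metabotropic glutamate receptor 5: pyridyl swap

The source may hold more compounds than are shown below. What is called first, only, known or untested is meant among the compounds shown, and "the series" means these compounds.

Compound 1 `Cc1cccc(C(=O)N[C@H]2CCC[C@H](NC(=O)c3ccccn3)C2)c1` and compound 2 `O=C(NC1CCCC(NC(=O)c2cccc(Cl)c2)C1)c1cccc(Cl)c1` share a cyclohexane-1,3-diyl bis-amide core. Within the data shown here, in a functional assay on HEK293 cells for antagonist activity at metabotropic glutamate receptor 5 (Homo sapiens), read by FLIPR and calcium flux (on this read-out higher numbers stand for weaker inhibition and lower numbers for stronger inhibition), compound 1 gives 1000 nM, the highest of the two numbers known so far; compound 2 gives 139 nM, a lower number, and the gap between the two lies beyond the usual scatter. The two differ in both aryl groups and in stereochemical definition, so no single change can be read from them.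

Compound 3 `O=C(N[C@H]1CCC[C@H](NC(=O)c2ccccn2)C1)c1ccccn1` is not yet measured. It differs from compound 1 by pyridin-2-yl in place of 3-methylphenyl on a carbonyl carbon, making the two amide arms identical. Among the measured compounds shown here, no measured pair isolates this change. In this assay a step from compound 1 to compound 3 of about a 1.5-fold higher number from compound 1 to compound 3 (0.18 log units; within the scatter) is expected, small and possibly within scatter, with a slight lean toward a higher number. Compound 3 is therefore estimated at 1500 nM, with a range of 500 nM to 5000 nM.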

Compound 3, half-maximal inhibitory concentration: 1150 nM
Estimate against measurement, compound 3: 1.3-fold (0.12 log units) above; the range from low to high includes it.
By their numbers in this assay, from the lowest: compound 2; then compounds 1 and 3 (each within the scatter of the next).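

Pyridin-2-yl in place of 3-methylphenyl on a carbonyl carbon is the first single change in the series that can be read, and this assay shows a 1.2-fold higher number from compound 1 to compound 3 (0.06 log units; within the scatter) for it. At this position, therefore, exchanging the all-carbon aromatic ring for one with a ring nitrogen does not separate compound 3 from compound 1, even with the two amide arms made identical. No measurement at hand offers an explanation for this result.

Among these compounds, no single step links compound 2, with 139 nM, to either of the others, so that value cannot be assigned to any one group or to stereochemistry. Also open, on these data alone, is whether a pyridin-3-yl ring or a 3-methoxyphenyl group on this carbonyl carbon would shift the number beyond the scatter.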